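Methoxy step carried over to a second core

The compounds below may be only part of what the source reports. "The series", "measured", "known", "first", "only" and "open" are said of these compounds alone.

Compound 1 `COc1cc(CNC(=O)/C=C/c2ccccc2)ccc1OCc1nc(C)c(C)nc1C` and compound 2 `COc1ccccc1/C=C/C(=O)NCc1ccc(OCc2nc(C)c(C)nc2C)c(OC)c1` share one core; compound 3 `COc1cccc(/C=C/C(=O)NCc2ccc(O)c(OC)c2)c1` and compound 4 `COc1cc(CNC(=O)/C=C/c2cccc(OC)c2OC)ccc1O` share another, and the difference between the two cores is not broken down here. In a functional assay on SH-SY5Y cells (Homo sapiens) for cytotoxicity, read by MTT assay, with stated times of 24 h and 4 h (on this read-out lower numbers stand for an effect already at smaller amounts and higher numbers for an effect only at larger amounts of compound), compound 1 gives 7310 nM and compound 2 gives 7150 nM, while compound 3 gives 5240 nM. The change from compound 1 to compound 2 is methoxy in place of hydrogen on an aromatic carbon, and it made a 1.0-fold lower number from compound 1 to compound 2 (0.01 log units; within the scatter). The change from compound 3 to compound 4 is methoxy in place of hydrogen on an aromatic carbon, the same kind of change; around its place it is additionally ortho to a methoxy group. Compound 4 is expected to give 5200 nM, with a range from 2600 nM to 10400 nM, because the earlier step came to a 1.0-fold lower number from compound 1 to compound 2 (0.01 log units; within the scatter). For compound 4 this means an expected step of a 1.0-fold lower number from compound 3 to compound 4 (0.00 log units; within the scatter).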

Compound 4, half-maximal effective concentration: 5490 nM
For compound 4 the middle estimate is 1.1-fold (0.02 log units) below the measured one; low and high end bracket the measured number.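

In this assay the step on the second core reads a 1.0-fold higher number from compound 3 to compound 4 (0.02 log units; within the scatter), and it agrees with the step on the first core: the same change on two cores in this assay, a 1.0-fold lower number (0.01 log units; within the scatter) from compound 1 to compound 2 and a 1.0-fold higher number (0.02 log units; within the scatter) from compound 3 to compound 4, 1.1-fold (0.03 log units) apart, within the scatter of two such steps. In these two pairs, methoxy in place of hydrogen on an aromatic carbon therefore carries over from one core to the other as a step within the scatter, also where the new group stands ortho to a methoxy group. Among these compounds, this shows only that neither core gives a detectable step, so there is no effect of measurable size to transfer, and it says nothing about other cores or other places on the ring.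

The compounds shown leave open whether an amine, a carboxylic acid or a longer chain such as ethoxy at that place would give a step beyond the scatter.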